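Benzyl to phenyl on the thiourea nitrogen: two cores

The compounds below may be only part of what the source reports. "The series", "measured", "known", "first", "only" and "open" are said of these compounds alone.

Compound 1 `CC(C)[C@H](NC(=S)NCc1ccccc1)c1nc2ccccc2[nH]1` and compound 2 `CC(C)[C@H](NC(=S)Nc1ccccc1)c1nc2ccccc2[nH]1` share one core and differ only at the thiourea substituent. In a functional assay on A549 cells (Homo sapiens) for cytotoxicity, read by MTT assay (on this read-out lower numbers stand for stronger inhibition and higher numbers for weaker inhibition), compound 1 gives 56100 nM and compound 2 gives 5200 nM. The change between them is phenyl in place of benzyl on an amide-type nitrogen, and the step is an 11-fold lower number from compound 1 to compound 2 (1.03 log units; beyond the scatter).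

Compound 3 `C[C@@H](NC(=S)NCc1ccccc1)c1nc2ccccc2[nH]1` carries a different core; how that core differs from the core of compound 1 is not broken down here. In this assay compound 3 gives 18700 nM, which places it between compound 1 and compound 2.

Compound 4 `C[C@@H](NC(=S)Nc1ccccc1)c1nc2ccccc2[nH]1` is not yet measured. It differs from compound 3 by phenyl in place of benzyl on an amide-type nitrogen, the same change as from compound 1 to compound 2, at the same place. With one measured example only, the expectation is that the step from compound 3 to compound 4 in this assay will run in the same direction and of roughly comparable size, tempered in that the core of compound 3 is not the core of compound 1 and the change has been seen only once; the expected step is a 7.5-fold lower number from compound 3 to compound 4 (0.87 log units; beyond the scatter). On that basis, compound 4 is expected to give about 2500 nM in this assay, with the likely range from 800 nM to 8000 nM.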

Compound 4, half-maximal inhibitory concentration: 14800 nM
Compound 4: middle estimate off by 5.9-fold (0.77 log units), on the low side, outside the stated range (above it).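

In this assay, phenyl in place of benzyl on the amide-type nitrogen gives a 1.3-fold lower number from compound 3 to compound 4 (0.10 log units; within the scatter), so on the core of compound 3 the change leaves no readable difference in cytotoxicity. Set beside the earlier step, the same change does not carry over in size from the core of compound 1 to the core of compound 3: the same change on two cores in this assay, an 11-fold lower number (1.03 log units; beyond the scatter) from compound 1 to compound 2 and a 1.3-fold lower number (0.10 log units; within the scatter) from compound 3 to compound 4, 8.5-fold (0.93 log units) apart, beyond the scatter of two such steps This shows that, in this series, the large step seen on the core of compound 1 cannot be treated as a fixed increment to add to another core, but with only two matched pairs it does not show what sets the two cores apart, nor how the change would behave on any further core.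

Open, going by these compounds, is whether the sharp response belongs to the core of compound 1 alone or also appears on other cores, and whether a longer chain such as phenylethyl on the amide-type nitrogen would follow the benzyl or the phenyl compounds on each core. Also open, on these data alone, is how an amine or a carboxylic acid on the phenyl ring would read on the two cores.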